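Swapping a five-membered sugar for a six-membered one

The source may report more compounds than this note shows. Statements on the series, on what has been measured and on what is new or still open speak of the compounds shown alone.

The three measured compounds share a core, each carrying a different sugar-like group on an aromatic nitrogen of the triazole. Compound 1 `CC1(C)O[C@@H](CO)[C@H](Cn2cc(Cn3c4c(c5ccccc53)C(=O)c3c[n+]([O-])c5ccccc5c3C4=O)nn2)O1` gives 370 nM in a functional assay on A549 cells (Homo sapiens) for cytotoxicity, read by MTT assay, with a stated time of 72 h; a higher number here means a weaker inhibitor, a lower number a stronger inhibitor. Compound 2 `O=C1c2c[n+]([O-])c3ccccc3c2C(=O)c2c1c1ccccc1n2Cc1cn([C@@H]2C[C@H](O)[C@@H](CO)O2)nn1` gives 120 nM in this assay, and compound 3 `O=C1c2c[n+]([O-])c3ccccc3c2C(=O)c2c1c1ccccc1n2Cc1cn([C@H]2O[C@H](CO)[C@@H](O)[C@H]2O)nn1` gives 2680 nM. Compound 3 therefore stands highest of the three, that is the weakest inhibitor, with the gap to its nearest neighbour given by a 7.2-fold higher number from compound 1 to compound 3 (0.86 log units; beyond the scatter) and the gap to its furthest given by a 22-fold higher number from compound 2 to compound 3 (1.35 log units; beyond the scatter).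

Compound 4 `O=C1c2c[n+]([O-])c3ccccc3c2C(=O)c2c1c1ccccc1n2Cc1cn([C@@H]2O[C@H](CO)[C@@H](O)[C@H](O)[C@H]2O)nn1` is not yet measured. It differs from compound 3 by 3,4,5-trihydroxy-6-(hydroxymethyl)oxan-2-yl in place of 3,4-dihydroxy-5-(hydroxymethyl)oxolan-2-yl on an aromatic nitrogen. The entering group is larger, has one more hydrogen-bond donor and one more acceptor, and its ring has six members rather than five.

For the measured compounds named here, the step most relevant here is the one from compound 2 to compound 3, where the addition of a single hydroxy group on a saturated ring carbon brought a 22-fold higher number from compound 2 to compound 3 (1.35 log units; beyond the scatter). Compound 4 adds yet another hydroxy group and widens the ring, so a further weakening is expected, though perhaps more modest than that earlier step. Compound 4 is therefore estimated to give 6000 nM, with a range from 1800 nM to 20000 nM, meaning an expected step of a 2.2-fold higher number from compound 3 to compound 4 (0.35 log units; beyond the scatter).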

Compound 4, half-maximal inhibitory concentration: 560 nM
Compound 4: the middle estimate sits 11-fold (1.03 log units) above what was measured; the measured number lies below the stated range.
By their numbers in this assay, from the lowest: compound 2; then compounds 1 and 4 (each within the scatter of the next); then compound 3.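

In this assay, the move from the five-membered 3,4-dihydroxy-5-(hydroxymethyl)oxolan-2-yl to the six-membered 3,4,5-trihydroxy-6-(hydroxymethyl)oxan-2-yl gives a 4.8-fold lower number from compound 3 to compound 4 (0.68 log units; beyond the scatter), so at this position on the triazole a further hydroxy group does not always go with a higher number, as the step from compound 2 to compound 3 alone might have suggested. The six-membered sugar still gives a 4.7-fold higher number from compound 2 to compound 4 (0.67 log units; beyond the scatter), which leaves the sugar with the fewest hydroxy groups as the best of these groups, while a 1.5-fold higher number from compound 1 to compound 4 (0.18 log units; within the scatter) shows that the protected group of compound 1 and the six-membered sugar cannot be told apart in this assay despite their different shapes. No measurement offered here explains why the larger sugar recovers activity.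

Ring size and the extra hydroxymethyl-bearing carbon change together in this step, so their separate contributions remain unknown. The compounds shown also leave open how this position would respond to a sugar carrying an amine or a carboxylic acid in place of one of its hydroxy groups.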